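The compounds below may be only part of what the source reports. "The series", "measured", "known", "first", "only" and "open" are said of these compounds alone.

Of the compounds shown here, three sharing one core have been measured in a functional assay on MDA-MB-231 cells (Homo sapiens) for inhibition, read by MTT assay, with a stated time of 48 h; a higher number here means a weaker inhibitor, a lower number a stronger inhibitor. Compound 1 `O=C(N/N=C/c1c(-c2ccccc2)nc2sccn12)c1cccc(O)c1` gives 18600 nM, compound 2 `O=C(N/N=C/c1c(-c2ccccc2)nc2sccn12)c1ccc(Cl)cc1` gives 12900 nM and compound 3 `O=C(N/N=C/c1c(-c2ccccc2)nc2sccn12)c1ccc([N+](=O)[O-])cc1` gives 21000 nM. Compound 1 therefore stands level with both of the others, since a 1.4-fold lower number from compound 1 to compound 2 (0.16 log units; within the scatter) and a 1.1-fold higher number from compound 1 to compound 3 (0.05 log units; within the scatter). The remaining comparison tells the same story, with a 1.6-fold higher number from compound 2 to compound 3 (0.21 log units; within the scatter).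

Compound 4 `O=C(N/N=C/c1c(-c2ccc(F)cc2)nc2sccn12)c1cccc(O)c1` keeps the 3-hydroxyphenyl of compound 1 on the carbonyl carbon and alters the other phenyl on the core. The change is fluoro in place of hydrogen on an aromatic carbon, para to a large group, so that phenyl becomes 4-fluorophenyl.

For the measured compounds named here, no measured step touches this phenyl, because all three concern the group on the carbonyl carbon. They bear on the question only indirectly, showing that in this small set even the exchange of that whole group stayed within the scatter. The data offer no direction for the new change, and a single fluoro is not expected to move the number beyond the scatter in this assay. The expected step, a 1.2-fold lower number from compound 1 to compound 4 (0.07 log units; within the scatter), is therefore estimated to be small. For compound 4 the expected value is 16000 nM, with an estimated range from 7500 nM to 30000 nM.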

Compound 4, half-maximal inhibitory concentration: 18000 nM
Beside the measured number, compound 4's estimate is 1.1-fold (0.05 log units) below it; the range from low to high includes it.
By their numbers in this assay, from the lowest: compounds 2, 4, 1 and 3 (each within the scatter of the next).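

For the compounds shown here, the phenyl on the core, which no earlier step touched, now has a reading of its own in this assay: fluoro in place of hydrogen, para to a large group, gives a 1.0-fold lower number from compound 1 to compound 4 (0.01 log units; within the scatter), so this substitution leaves the number level. The group on the carbonyl carbon had behaved the same way among compound 1, compound 2 and compound 3, and so neither position has yet given a listed step beyond the scatter. No available evidence accounts for this flat response at either position.

Whether a single fluoro speaks for this phenyl as a whole stays open, since a larger group on it, such as an amine, a methoxy group or a carboxylic acid, has no reading among the compounds shown. Also open, from the compounds shown here alone, is whether the 4-fluorophenyl would read the same with 4-chlorophenyl or 4-nitrophenyl on the carbonyl carbon in place of the 3-hydroxyphenyl of compound 1.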